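The source may hold more compounds than are shown below. What is called first, only, known or untested is meant among the compounds shown, and "the series" means these compounds.

Working notes on the series. In an ADME assay on Raji cells (Homo sapiens) for cytotoxicity, read by luminescence, with a stated time of 72 h (a higher number here means that more compound is needed for the effect, a lower number that less compound is needed), compound 1 (`CCOC(=O)c1c(-c2cccc(OC)c2)[nH]c2cc(OC)c(OC)cc2c1=O`) gives > 21500 nM, which is a limit of the assay. Compound 2 (`CCOC(=O)c1c(-c2cccc(-c3ccccc3)c2)[nH]c2cc(OC)c(F)cc2c1=O`) gives > 21500 nM, also a limit, so no number is available for it. Compound 3 (`CCOC(=O)c1c(-c2cccc(OC)c2)[nH]c2cc(OC)c(F)cc2c1=O`) carries methoxy in place of phenyl on an aromatic carbon, meta to a large group (methoxy in place of phenyl on an aromatic carbon). Going by the values given here, with no measured step, the only guide is the limit of > 21500 nM in this assay, at which 2 of the 2 values shown sit. The expected change a step that the limit leaves unreadable from compound 2 to compound 3 is none beyond the scatter, with no direction expected. For compound 3 the estimated value in this assay is 28000 nM, with an expected range of 12000 nM to 60000 nM.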

Compound 3, half-maximal effective concentration: > 21500 nM
Compound 3: a limit, no number; the forecaster's own chance of this, stated with the estimate: 85%; the middle value is on the limit's open side.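

Compound 3 also sits at a limit, > 21500 nM, so its steps from compound 1 and compound 2 cannot be read: the limit of > 21500 nM in this assay, at which 3 of the 3 values shown sit.
In this assay the compounds shown leave open whether methoxy in place of phenyl, or fluoro in place of methoxy, changes the read-out at all.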